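The compounds below may be only part of what the source reports. "The series", "measured", "known", "first", "only" and "open" are said of these compounds alone.

Measured so far:
compound 1 `COc1ccccc1Oc1ccc2c(NCCCNCc3ccco3)ccnc2c1` gives 317 10^-6 cm/s in an ADME assay for permeability, using PAMPA, with a stated time of 30 min, at pH 7.4; on this read-out lower numbers stand for lower permeability and higher numbers for higher permeability
compound 2 `COc1cccc(CNCCCNc2ccnc3cc(Oc4ccc(Cl)cc4)ccc23)c1O` gives 317 10^-6 cm/s in this assay

Compound 2 stands level with compound 1 at the digits shown; the two values show no difference that goes beyond the usual scatter of such measurements, so nothing can be said of either being more or less permeable than the other. Compound 3 `CCC(CC)c1ccc2c(NCCCNCc3cccc(OC)c3O)ccnc2c1` has not yet been measured in this assay. It differs from compound 2 in a single place: pentan-3-yl in place of 4-chlorophenoxy on an aromatic carbon. Going by the values given here, no step between two measured compounds is available to show how a change of this kind moves the read-out, and the two values at hand sit at the same level. The step of a 1.1-fold lower number from compound 2 to compound 3 (0.02 log units; within the scatter) is therefore expected to be none beyond the scatter. For compound 3 the estimated value in this assay is 300 10^-6 cm/s, with a range from 150 10^-6 cm/s to 600 10^-6 cm/s.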

Compound 3, apparent permeability: 23 10^-6 cm/s
Estimate against measurement, compound 3: 13-fold (1.12 log units) above, outside the stated range (below it).
By their numbers in this assay, from the lowest: compound 3; then compounds 1 and 2 (each within the scatter of the next).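

In this assay this aromatic carbon is not a neutral place on the shared core: pentan-3-yl in place of 4-chlorophenoxy goes with a 14-fold lower number from compound 2 to compound 3 (1.14 log units; beyond the scatter) and is a large step. Going by these compounds alone, the level shared by the two earlier values therefore does not hold across this change, and this is the first step seen between compounds that differ in one place. The change removes a six-membered aromatic ring of carbon only and a hydrogen-bond acceptor and brings in a group with no ring, but nothing available bears on why the number moves.

Which part of 4-chlorophenoxy carries the step stays open, as the ring, the oxygen and the chlorine all leave together. On these data alone, how phenoxy without the chlorine, cyclohexyl or an amine on this carbon would read remains unknown from these compounds.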